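The compounds below may be only part of what the source reports. "The series", "measured", "known", "first", "only" and "open" are said of these compounds alone.

Working notes on the benzamide series.

Going by the values given here, the series so far comprises compound 1 `Nc1ccccc1NC(=O)/C=C/c1ccc(CSc2ccc(F)cc2)cc1`, compound 2 `COc1ccc(SCc2ccc(C(=O)Nc3ccccc3N)cc2)cc1` and compound 3 `CC(C)(C)c1ccc(SCc2ccc(/C=C/C(=O)Nc3ccccc3N)cc2)cc1`, with compound 4 `Cc1cc(C)cc(SCc2ccc(C(=O)Nc3ccccc3N)cc2)c1` still to be tested. Among the compounds with values here, in a functional assay on SMMC-7721 cells (Homo sapiens) for antiproliferative activity, read by CCK-8 assay, with a stated time of 72 h (on this read-out lower numbers stand for stronger inhibition and higher numbers for weaker inhibition), compound 2 gives 2170 nM, and this is the only number the series has in this assay: compound 1 is recorded as "not determined" (no result reported) and compound 3 as "not determined" (no result reported), so compound 2 cannot be placed against any neighbour and no measured step exists to set a scale.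

Compound 4 differs from compound 2 in one place: 3,5-dimethylphenyl in place of 4-methoxyphenyl on a sulfur. Within the data shown here, nothing among the measured compounds tells how a change at the sulfur-linked aryl group moves this read-out, so the expectation rests only on the single value of compound 2 and on the change being a like-for-like swap of one aryl group for another of equal size. On that basis the step from compound 2 to compound 4 in this assay is expected to stay within the usual scatter, with no direction claimed, giving an expected 1.1-fold lower number from compound 2 to compound 4 (0.04 log units; within the scatter).

For compound 4 the estimate in this assay is therefore 2000 nM, within a range from 700 nM to 6000 nM.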

Compound 4, half-maximal inhibitory concentration: 2760 nM
For compound 4 the middle estimate is 1.4-fold (0.14 log units) below the measured one; low and high end bracket the measured number.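

In this assay, going by these compounds alone, the series now has its first measured step, a 1.3-fold higher number from compound 2 to compound 4 (0.10 log units; within the scatter), and that step gives the first scale for a change at the aryl group on the sulfur. The pair shows that 3,5-dimethylphenyl and 4-methoxyphenyl are not separated by this read-out, even though the swap replaces an oxygen-bearing group with one of carbon only and the same heavy-atom count; this holds for this one pair and sets no rule for the position. No measurement at hand bears on why the two groups read alike.

The compounds shown leave open whether this position stays as flat with a different kind of substituent on the aryl ring, such as an amine or a carboxylic acid, or with a longer chain in place of the aryl group, so how far the read-out can move here remains unknown. Steps involving compound 1 and compound 3 cannot be read, so it also remains open whether the same swap would behave alike in their scaffold.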